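Swapping One Ring Group on Compound 2

The compounds below may be only part of what the source reports. "The series", "measured", "known", "first", "only" and "open" are said of these compounds alone.

Measured in a functional assay on A498 cells (Homo sapiens) for cytotoxicity; on this read-out lower numbers stand for stronger inhibition of growth and higher numbers for weaker inhibition of growth:
- compound 1 `COc1ccc(C2=C(c3cc(OC)c(OC)c(OC)c3)CC3CCCN3C2=O)cc1O`: > 100000 nM (a limit, not a number)
- compound 2 `CSc1ccc(C2=C(c3ccc(F)c(C)c3)C(=O)N3CCCC3C2)cc1`: 300 nM
- compound 3 `COc1ccc(C2=C(c3ccc(SC)cc3)CC3CCCN3C2=O)cc1OC`: 8000 nM

Of the two true numbers here, compound 2 holds the lower, at 300 nM. Its nearest neighbour is compound 3 at 8000 nM, a gap well beyond the usual scatter of repeated measurements.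

The next compound is compound 4 `CSc1ccc(C2=C(c3ccc(SC)cc3)C(=O)N3CCCC3C2)cc1`, which differs from compound 2 in one place: 4-(methylsulfanyl)phenyl in place of 4-fluoro-3-methylphenyl on a double-bonded ring carbon. A 4-(methylsulfanyl)phenyl group stands in place of the 4-fluoro-3-methylphenyl group on a double-bonded ring carbon, so the same group would then appear twice on the shared core.

Within the data shown here, no measured pair isolates this swap, so any expectation is a judgement. Compound 3 also carries a 4-(methylsulfanyl)phenyl group and gives 8000 nM, which points towards a higher number rather than a lower one. The expected change in this assay is a 3.3-fold higher number from compound 2 to compound 4 (0.52 log units; beyond the scatter), a moderate loss of growth inhibition. For compound 4 the estimate is 1000 nM, with an expected range of 200 nM to 6000 nM.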

Compound 4, concentration for 50% growth inhibition: 15000 nM
The estimate for compound 4 lay 15-fold (1.18 log units) below the measured number; measured number above the stated range.
By their numbers in this assay, from the lowest: compound 2; then compounds 3 and 4 (each within the scatter of the next). At a limit, above all of these: compound 1.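

In this assay, among these compounds, replacing 4-fluoro-3-methylphenyl with 4-(methylsulfanyl)phenyl on the double-bonded ring carbon gives a 50-fold higher number from compound 2 to compound 4 (1.70 log units; beyond the scatter), the first single-place comparison in this set. It shows that growth inhibition depends strongly on the group at this position, even though both groups contain 8 heavy atoms and one six-membered aromatic ring of carbon only. The compounds shown do not explain why this change has so large an effect.

As far as these compounds go, it remains open whether the fluorine, the methyl or both account for the better value of compound 2. Also open, from the compounds shown here alone, is how a phenyl ring carrying an amine or a carboxylic acid would behave on this carbon in this assay.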